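A few compounds are considered here, and "the series" means these few. Any claim that something is new, unique, unknown or untested is made for them only; others in the source may bear on it.

Measured compounds:
compound 1, `C=C(c1ccc(OC)cc1NC(=O)CN)c1ccc(OC)c2c1OC(C)(C)C=C2`, 190 nM
compound 2, `C=C(c1cc(OC)c(OC)c(OC)c1)c1ccc(OC)cc1NC(=O)CN`, 60 nM
compound 3, `C=C(c1ccc(OC)cc1NC(=O)CNC)c1ccc(OC)c2c1OC(C)(C)C=C2`, 320 nM

These three compounds were tested in a functional assay on HCT-8 cells (Homo sapiens) for antiproliferative activity, read by MTT assay, with a stated time of 48 h; on this read-out higher numbers stand for weaker inhibition and lower numbers for stronger inhibition. Compound 2 gives the lowest number of the three; compound 1 gives a number that stands beyond the scatter from it, and compound 3 stands further away still. How the core of compound 1 differs from the core of compound 2 is not broken down here, so only their values can be compared.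

Compound 3 differs from compound 1 by a single change, (methyl in place of hydrogen on an amine nitrogen), and in this assay that change made a 1.7-fold higher number from compound 1 to compound 3 (0.23 log units; within the scatter).

Compound 4, `C=C(c1cc(OC)c(OC)c(OC)c1)c1ccc(OC)cc1NC(=O)CNC`, has not yet been measured. Within the data shown here, it differs from compound 2 by methyl in place of hydrogen on an amine nitrogen, the same change, at the same kind of place, as the one from compound 1 to compound 3. Resting on that earlier step, the step from compound 2 to compound 4 in this assay is expected to be a 1.7-fold higher number from compound 2 to compound 4 (0.22 log units; within the scatter). Compound 4 is therefore estimated at 100 nM, expected to fall between 50 nM and 200 nM.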

Compound 4, half-maximal inhibitory concentration: 190 nM
The estimate for compound 4 lay 1.9-fold (0.28 log units) below the measured number, and the stated range covers the measured number.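

On the core of compound 2, methyl in place of hydrogen on the amine nitrogen gave a 3.2-fold higher number from compound 2 to compound 4 (0.50 log units; beyond the scatter) in this assay. Set beside the same change on the core of compound 1, this step cannot be told apart from the earlier one: the same change on two cores in this assay, a 1.7-fold higher number (0.23 log units; within the scatter) from compound 1 to compound 3 and a 3.2-fold higher number (0.50 log units; beyond the scatter) from compound 2 to compound 4, 1.9-fold (0.27 log units) apart, within the scatter of two such steps These two pairs show that the change carried from one core to the other with a similar outcome, but they do not show that it would do so on any further core, or why one step lies beyond the scatter and the other within it.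

The compounds shown stop at methyl on this nitrogen, which leaves open how a larger group such as ethyl, or a second methyl giving a dimethylamino group, would read on either core. Also open, from the compounds shown here alone, is what a longer chain between the carbonyl and the amine would do, or a carboxylic acid in place of the amine.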